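Shifting the Methoxy Group on a Sulfonamide Benzamide Series

The source may report more compounds than this note shows. Statements on the series, on what has been measured and on what is new or still open speak of the compounds shown alone.

Compound 1 `COc1ccc(-n2cc(NC(=O)c3cccc(NS(=O)(=O)c4ccc(Cl)cc4)c3)cn2)cc1`, 29700 nM in a functional assay on A549 cells (Homo sapiens) for inhibition, read by MTT assay, with a stated time of 48 h; a higher number here means a weaker inhibitor, a lower number a stronger inhibitor; compound 2 `COc1cccc(-n2cc(NC(=O)c3cccc(NS(=O)(=O)c4ccc(Cl)cc4)c3)cn2)c1`, 44400 nM in this assay; compound 3 `COc1ccc(-n2cc(NC(=O)c3ccc(NS(=O)(=O)c4ccccc4)cc3)cn2)cc1`, 85800 nM in this assay.

From compound 1 to compound 2 a single change is made, (3-methoxyphenyl in place of 4-methoxyphenyl on an aromatic nitrogen), and it moves the number by a 1.5-fold higher number from compound 1 to compound 2 (0.17 log units; within the scatter). Compound 4 `COc1cccc(-n2cc(NC(=O)c3ccc(NS(=O)(=O)c4ccccc4)cc3)cn2)c1` carries the same change relative to compound 3, (3-methoxyphenyl in place of 4-methoxyphenyl on an aromatic nitrogen), with the place described in the same words for both pairs. How the core of compound 3 differs from the core of compound 1 is not broken down here. Since compound 1 and compound 2 sit within the scatter of each other, the step from compound 3 to compound 4 is expected to be of similar size, a 1.4-fold higher number from compound 3 to compound 4 (0.15 log units; within the scatter). Compound 4 is therefore estimated at 120000 nM in this assay, between 60000 nM and 250000 nM.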

Compound 4, half-maximal inhibitory concentration: > 100000 nM
Compound 4 gave a limit, no number (the forecaster's own chance of this, stated with the estimate: 25%); the middle value is on the limit's open side.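

In this assay compound 4 gives > 100000 nM, which is a limit of the assay and not a number. The change from 4-methoxyphenyl to 3-methoxyphenyl on the core of compound 3 can therefore be read only as a floor, an at least 1.1-fold higher number from compound 3 to compound 4 (0.06 log units; that floor lies within the scatter), and this neither shows that the change carries over with the same size nor shows that it differs between the two cores: the same change on two cores in this assay, a 1.5-fold higher number (0.17 log units; within the scatter) from compound 1 to compound 2 and an at least 1.1-fold higher number (0.06 log units; that floor lies within the scatter) from compound 3 to compound 4; the limit leaves it open whether they differ. From the compounds shown here alone, the true size of the step on this core remains unknown, since its upper end is hidden by the limit: the limit of > 100000 nM in this assay, at which 1 of the 4 values shown sits.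

The compounds shown leave open how an amine, a carboxylic acid or a longer chain such as ethoxy in place of the methoxy group would read on either core. They also leave open which of the differences between the two cores accounts for the gap between compound 1 and compound 3.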